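Third Fluorine Added, Little Change in Inhibition Expected

The source may report more compounds than this note shows. Statements on the series, on what has been measured and on what is new or still open speak of the compounds shown alone.

In an assay on CHO cells for displacement of a labelled ligand from adenosine receptor A3 (Homo sapiens), read by scintillation counting, with a stated time of 120 min, tested at 10 uM (on this read-out lower numbers stand for less inhibition and higher numbers for more inhibition at the one concentration tested (going by the name of the read-out)), compound 1 `Nc1scc(CN2CCN(c3ccc(Cl)cc3F)CC2)c1C(=O)c1ccc(Cl)cc1` gives 1% and compound 2 `Nc1scc(CN2CCN(c3cc(F)ccc3F)CC2)c1C(=O)c1ccc(Cl)cc1` gives 2%; these two values sit within the scatter of each other, and the step of a number 1 percentage points higher from compound 1 to compound 2 (within the scatter) therefore tells nothing about a real difference. Compound 3 `Nc1scc(CN2CCN(c3c(F)cc(F)cc3F)CC2)c1C(=O)c1ccc(Cl)cc1` has not been measured. Its change from compound 2 is 2,4,6-trifluorophenyl in place of 2,5-difluorophenyl on an amine nitrogen in a ring. Going by the values given here, the only measured step, which also swapped one fluorinated ring for another, stayed within the scatter, so no step beyond the scatter is expected in no change at the digits printed from compound 2 to compound 3 (within the scatter) for this assay. Compound 3 is thus expected to give about 2%, within a range from -8% to 12%.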

Compound 3, a percentage reported as inhibition, at one concentration (the size of the read-out at that concentration, not a potency): 0%
For compound 3 the middle estimate is 2 percentage points above the measured one, within the range that was stated.
By their numbers in this assay, from the lowest: compounds 3, 1 and 2 (each within the scatter of the next).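

In this assay, placing 2,4,6-trifluorophenyl on the amine nitrogen in the ring gives a number 2 percentage points lower from compound 2 to compound 3 (within the scatter), and the same group gives a number 1 percentage points lower from compound 1 to compound 3 (within the scatter). A third fluorine on this phenyl ring therefore separates it from neither of the earlier groups, and all three halogenated phenyl groups give small values at the one concentration tested. No measurement here offers an explanation for these readings. From the compounds shown here alone, it remains open whether a phenyl ring carrying an amine or a carboxylic acid would read differently. Going by these compounds, a longer chain at this nitrogen is equally open.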